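This account rests on a few compounds, and the source may have more. Where it says the series, first, only, none or still open, it means among the compounds named here.

Measured compounds:
- compound 1 `Cc1c(C(=O)N/N=C\c2ccccc2O)oc2cccc(O)c12`: 8350 nM
- compound 2 `Cc1c(C(=O)N/N=C\c2c(O)cccc2Cl)oc2cccc(O)c12`: 18700 nM
- compound 3 `Cc1c(C(=O)N/N=C\c2cc([N+](=O)[O-])ccc2O)oc2cccc(O)c12`: 17100 nM

In a functional assay on PC-3 cells (Homo sapiens) for inhibition (a lower number here means a stronger inhibitor, a higher number a weaker inhibitor), compound 2 gives the highest number of the three; its nearest neighbour is compound 3, within the scatter, and compound 1 lies furthest from it. For the measured compounds named here, the only single change reaching compound 2 is a 2.2-fold higher number from compound 1 to compound 2 (0.35 log units; beyond the scatter); the parallel change a 2.0-fold higher number from compound 1 to compound 3 (0.31 log units; beyond the scatter) is of similar size.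

Compound 4 `COc1ccccc1/C=N\NC(=O)c1oc2cccc(O)c2c1C` is not yet measured. Relative to compound 2 the change is 2-methoxyphenyl in place of 2-chloro-6-hydroxyphenyl on a carbon with a double bond to nitrogen. This removes the chloro whose addition gave a 2.2-fold higher number from compound 1 to compound 2 (0.35 log units; beyond the scatter), so that part of the change is expected to undo a modest step; the exchange of the hydroxyl for a methoxy on that ring has no measured counterpart among these compounds, so its effect is unknown. The expectation for compound 4 in this assay is therefore a number near that of compound 1, with wide uncertainty, which means an expected step of a 1.9-fold lower number from compound 2 to compound 4 (0.27 log units; within the scatter). The estimate for compound 4 is 10000 nM, between 4000 nM and 30000 nM.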

Compound 4, half-maximal inhibitory concentration: 32700 nM
The estimate for compound 4 lay 3.3-fold (0.51 log units) below the measured number; measured number above the stated range.
By their numbers in this assay, from the lowest: compound 1; then compounds 3, 2 and 4 (each within the scatter of the next).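

In this assay, for the compounds shown here, methyl in place of hydrogen on an oxygen on an aromatic ring gives a 3.9-fold higher number from compound 1 to compound 4 (0.59 log units; beyond the scatter), the first change at that oxygen, and compound 1 keeps the lowest number, with no compound going against this among the four. The exchange of 2-chloro-6-hydroxyphenyl for 2-methoxyphenyl gives a 1.7-fold higher number from compound 2 to compound 4 (0.24 log units; within the scatter), so a compound without the chloro but with the methoxy does not return to the level of compound 1, and the free hydroxyl on this ring appears to count for more than the absence of the chloro. Nothing available explains why the oxygen substituent affects the number.

Open, on these data alone, is whether a longer chain such as ethoxy, or an amine in place of the hydroxyl, would follow the methoxy. Also open, as far as these compounds go, is how a chloro would act on the ring of compound 4.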